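Replacing 1,3-Benzothiazol-2-yl with Pyridin-4-yl on a Shared Core

The compounds below may be only part of what the source reports. "The series", "measured", "known", "first", "only" and "open" are said of these compounds alone.

In a functional assay on PC-3 cells (Homo sapiens) for inhibition, read by CellTiter-Glo, with a stated time of 72 h (on this read-out higher numbers stand for lower toxicity in this test and lower numbers for higher toxicity in this test), compound 2 `CC1=C(CC(=O)NCCN2CCCC2)c2cc(F)ccc2/C1=C\c1nc2ccccc2s1` gives 4940 nM, the lowest of three numbers and so the most toxic of the three in this test. Compound 3 `CC1=C(CC(=O)N2CCN(c3ccncc3)CC2)c2cc(F)ccc2/C1=C\c1nc2ccccc2s1` gives 12300 nM, and compound 1 `CC1=C(CC(=O)NCCN(C)C)c2cc(F)ccc2/C1=C\c1ccncc1` gives 28900 nM. The next compound, compound 4 `CC1=C(CC(=O)NCCN2CCCC2)c2cc(F)ccc2/C1=C\c1ccncc1`, keeps the amide side chain of compound 2 and changes one group: pyridin-4-yl in place of 1,3-benzothiazol-2-yl on a double-bonded chain carbon bound to a double-bonded ring carbon. Going by the values given here, no measured step covers this swap directly. Among the compounds with values here, the only measured step, a 2.5-fold higher number from compound 2 to compound 3 (0.40 log units; beyond the scatter), changes the amide end instead, and its size is modest. The closest guide is compound 1, which already carries pyridin-4-yl at this place, though with a different amide end, and gives 28900 nM. That single value suggests that compound 4 will show a higher number than compound 2, although one compound is thin evidence. The estimated change in this assay is a 3.6-fold higher number from compound 2 to compound 4 (0.56 log units; beyond the scatter). Compound 4 is expected at about 18000 nM, with an estimated range from 7000 nM to 40000 nM.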

Compound 4, half-maximal cytotoxic concentration: 10200 nM
For compound 4 the middle estimate is 1.8-fold (0.25 log units) above the measured one, and the stated range covers the measured number.
By their numbers in this assay, from the lowest: compound 2; then compounds 4 and 3 (each within the scatter of the next); then compound 1.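

In this assay, the swap of 1,3-benzothiazol-2-yl for pyridin-4-yl on a double-bonded chain carbon bound to a double-bonded ring carbon can now be read directly with the amide side chain held fixed: there is a 2.1-fold higher number from compound 2 to compound 4 (0.31 log units; beyond the scatter) and the effect is modest. The result also adds a comparison at the far end of that side chain, with pyridin-4-yl kept in place, where pyrrolidin-1-yl in place of dimethylamino gives a 2.8-fold lower number from compound 1 to compound 4 (0.45 log units; beyond the scatter) and so also has a modest effect on the number. From the compounds shown here alone, what a plain phenyl ring or a carboxylic acid would give at the place of the pyridin-4-yl group stays open, as does whether the swap gives a similar step with other amide ends. The data shown offer no evidence on why either change moves the number.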